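Hydroxyphenyl placement on a shared pyridine-free core, DU-145 series

This account rests on a few compounds, and the source may have more. Where it says the series, first, only, none or still open, it means among the compounds named here.

Measured so far in a functional assay on DU-145 cells (Homo sapiens) for inhibition; on this read-out higher numbers stand for weaker inhibition and lower numbers for stronger inhibition:
compound 1, `Oc1cccc(-c2cc(-c3ccccc3OC(F)(F)F)cc(-c3ccccc3O)n2)c1`, > 50000 nM (a limit, not a number);
compound 2, `Oc1ccc(-c2cc(-c3ccccc3OC(F)(F)F)cc(-c3ccccc3O)n2)cc1`, 4190 nM;
compound 3, `Oc1cccc(-c2cc(-c3ccccc3OC(F)(F)F)cc(-c3cccc(O)c3)n2)c1`, 5420 nM.

The change 4-hydroxyphenyl in place of 3-hydroxyphenyl on an aromatic carbon made the step of an at least 11-fold lower number from compound 1 to compound 2 (1.07 log units; beyond the scatter); it rests on (the limit of > 50000 nM in this assay, at which 1 of the 3 values shown sits). The two cores differ by 3-hydroxyphenyl in place of 2-hydroxyphenyl on an aromatic carbon, with the step of an at least 9.2-fold lower number from compound 1 to compound 3 (0.96 log units; beyond the scatter). Compound 4, `Oc1ccc(-c2cc(-c3ccccc3OC(F)(F)F)cc(-c3cccc(O)c3)n2)cc1`, remains unmeasured. Its difference from compound 3 is 4-hydroxyphenyl in place of 3-hydroxyphenyl on an aromatic carbon: the same kind of change as from compound 1 to compound 2, but the place differs, being meta to a 3-hydroxyphenyl group rather than meta to a 2-hydroxyphenyl group. Compound 2 and compound 3 sit within the scatter of each other, so a smaller step is expected here, a 2.2-fold lower number from compound 3 to compound 4 (0.34 log units; beyond the scatter). Compound 4 is estimated at 2500 nM, between 800 nM and 8000 nM in this assay.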

Compound 4, half-maximal inhibitory concentration: 7760 nM
Estimate against measurement, compound 4: 3.1-fold (0.49 log units) below, and the stated range covers the measured number.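

In this assay, 4-hydroxyphenyl in place of 3-hydroxyphenyl gives a 1.4-fold higher number from compound 3 to compound 4 (0.16 log units; within the scatter), so this change does not carry from the core of compound 1 to the core of compound 3: the same change on two cores in this assay, an at least 11-fold lower number (1.07 log units; beyond the scatter) from compound 1 to compound 2 and a 1.4-fold higher number (0.16 log units; within the scatter) from compound 3 to compound 4, at least 17-fold (1.23 log units) apart, beyond the scatter of two such steps Likewise, 3-hydroxyphenyl in place of 2-hydroxyphenyl gives a 1.9-fold higher number from compound 2 to compound 4 (0.27 log units; within the scatter), which does not match its earlier step on the other core: the same change on two cores in this assay, an at least 9.2-fold lower number (0.96 log units; beyond the scatter) from compound 1 to compound 3 and a 1.9-fold higher number (0.27 log units; within the scatter) from compound 2 to compound 4, at least 17-fold (1.23 log units) apart, beyond the scatter of two such steps Steps such as an at least 6.4-fold lower number from compound 1 to compound 4 (0.80 log units; beyond the scatter) rest on a limit rather than a number, so the full size of these gaps stays unknown, and the result shows a core dependence for this pair of changes only, not a rule for the series: the limit of > 50000 nM in this assay, at which 1 of the 4 values shown sits.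

Open, as far as these compounds go, is how a core carrying two 4-hydroxyphenyl groups would read out. Also open, from the compounds shown here alone, is whether an amine or a carboxylic acid in place of the hydroxyl would show the same dependence on the core.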